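A few compounds are considered here, and "the series" means these few. Any claim that something is new, unique, unknown or untested is made for them only; others in the source may bear on it.

Compound 1 `CC(=O)N1CCN(c2ccc(Nc3ncc(C(F)(F)F)c(N4Cc5cccc(N(C)S(C)(=O)=O)c5C4)n3)cc2)CC1` gives 730 nM in a functional assay on HeLa cells (Homo sapiens) for antiproliferative activity, read by spectrophotometry, with a stated time of 2 days; on this read-out higher numbers stand for weaker inhibition of growth and lower numbers for stronger inhibition of growth.
Compound 2 `CN(c1cccc2c1CN(c1nc(Nc3ccc(C(F)(F)F)cc3)ncc1C(F)(F)F)C2)S(C)(=O)=O` gives > 30000 nM in this assay.

Compound 2 stands only at a limit of this assay, since its reading is the limit of > 30000 nM in this assay, at which 1 of the 2 values shown sits, and no number was reached. Going by the values given here, the only measured step, an at least 41-fold higher number from compound 1 to compound 2 (1.61 log units; beyond the scatter), is large, yet it concerns the change from compound 1 on an aromatic carbon, not the part of the molecule altered here. Compound 3 `CN(c1cccc2c1CN(c1nc(Nc3cc(Cl)cc(C(F)(F)F)c3)ncc1C(F)(F)F)C2)S(C)(=O)=O` differs from compound 2 by 3-chloro-5-(trifluoromethyl)phenyl in place of 4-(trifluoromethyl)phenyl on a nitrogen on an aromatic ring. Among the compounds with values here, no measured step bears on this change, so the shared core of compound 2 with a modified aryl amino group carries no guidance from the data. Compound 3 is therefore expected to remain near the limit, with an estimated step that the limit leaves unreadable from compound 2 to compound 3 in this assay. Compound 3 is estimated at 40000 nM, within the range 8000 nM to 100000 nM.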

Compound 3, concentration for 50% growth inhibition: 4300 nM
Estimate against measurement, compound 3: 9.3-fold (0.97 log units) above, outside the stated range (below it).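

Compound 2 does not mark a dead end for the aryl group on this nitrogen: 3-chloro-5-(trifluoromethyl)phenyl in place of 4-(trifluoromethyl)phenyl gives an at least 6.9-fold lower number from compound 2 to compound 3 (0.84 log units; beyond the scatter). The earlier step showed only a loss on replacing 4-acetylpiperazin-1-yl with trifluoromethyl, whereas this one shows that a ring without the acetylpiperazine can still give a number in this assay. The true size of the step stays unknown, since the reading of compound 2 is a limit and not a number: the limit of > 30000 nM in this assay, at which 1 of the 3 values shown sits.

The compounds shown do not separate the effect of the added chlorine from that of the different place of the trifluoromethyl group. As far as these compounds go, how a 3,5-dichlorophenyl group, or a phenyl ring carrying an amine or a carboxylic acid, would read on this nitrogen remains open.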